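Notes on the aryl piperazine series, compound 3 to compound 4

The source may report more compounds than this note shows. Statements on the series, on what has been measured and on what is new or still open speak of the compounds shown alone.

Among the compounds with values here, compound 3 `Nc1scc(CN2CCN(c3ccc(F)c(Cl)c3)CC2)c1C(=O)c1ccc(Cl)cc1` carries the lowest of the three numbers so far in a functional assay on CHO cells with adenosine receptor A1 (Homo sapiens) as the target, read by cAMP accumulation and immunoassay, with a stated time of 6 min, tested at 0.1 uM; a lower number here means a stronger effect, a higher number a weaker effect of the compound at the concentration tested: compound 3 gives -21%. Compound 1 `Nc1scc(CN2CCN(c3ccc([N+](=O)[O-])cc3)CC2)c1C(=O)c1ccc(Cl)cc1` gives -13%, and the step of a number 8 percentage points lower from compound 1 to compound 3 (within the scatter). Compound 2 `Nc1scc(CN2CCN(c3cccc4ccccc34)CC2)c1C(=O)c1ccc(Cl)cc1` gives 0%; the step of a number 21 percentage points lower from compound 2 to compound 3 (beyond the scatter). Compound 4 `Nc1scc(CN2CCN(c3cccc(Cl)c3)CC2)c1C(=O)c1ccc(Cl)cc1` differs from compound 3 by hydrogen in place of fluoro on an aromatic carbon. Within the data shown here, no measured step removes a single substituent from an otherwise kept aryl group; both measured steps exchange whole aryl groups, so neither bears closely on this change, and the loss of one fluoro is expected to move the number only slightly, if at all beyond the scatter. Compound 4 is therefore expected to give about -15%, between -35% and 5%, an expected step of a number 6 percentage points higher from compound 3 to compound 4 (within the scatter).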

Compound 4, a percentage reported as activity, at one concentration (the size of the read-out at that concentration, not a potency): -20%
For compound 4 the middle estimate is 5 percentage points above the measured one, and the stated range covers the measured number.
By their numbers in this assay, from the lowest: compounds 3, 4 and 1 (each within the scatter of the next); then compound 2.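

In this assay, within the data shown here, hydrogen in place of fluoro gives a number 1 percentage points higher from compound 3 to compound 4 (within the scatter) and thus the first reading on a single substituent within a kept aryl group: the fluoro can go without a change beyond the scatter. With a number 7 percentage points lower from compound 1 to compound 4 (within the scatter) the 3-chlorophenyl group stays unseparated from 4-nitrophenyl, and with a number 20 percentage points lower from compound 2 to compound 4 (beyond the scatter) it keeps the gap to naphthalen-1-yl. Nothing available explains these numbers.

Going by these compounds, the part played by the chloro stays open: an unsubstituted phenyl, or a methoxy or methyl group in place of the chloro, would test it.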